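A few compounds are considered here, and "the series" means these few. Any claim that something is new, unique, unknown or untested is made for them only; others in the source may bear on it.

Working notes on the series in an assay on cells for inhibition of Amine oxidase [flavin-containing] B (Homo sapiens), read by fluorescence, with stated times of 10 min and 20 min, tested at 25 uM; a lower number here means less inhibition, a higher number more inhibition at the concentration tested (going by the name of the read-out).

Of the compounds shown here, three have been measured. Compound 1 `CC(C)=CCc1c(O)cc(O)c(C=O)c1C` gives 36.3%. Going by the values given here, compound 3 `CC(C)=CCc1c(C)cc(O)cc1O` gives 4.2%; the step of a number 32.1 percentage points lower from compound 1 to compound 3 (beyond the scatter) is the only single-change comparison so far, and it concerns a formyl group on an aromatic carbon, not the side chain. Compound 2 `CC(C)=CCC/C(C)=C/CC1=C(C)C(=O)C(O)=C(O)C1=O` gives 92.2% and stands highest of the three numbers; compound 1 lies nearest, and compound 3 furthest, both beyond the scatter. Compound 2 also differs from the other two in its core, so its high number cannot be tied to any one feature.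

Compound 4 `CC(C)=CCC1=C(C)C(=O)C(O)=C(O)C1=O` is the next compound to be measured. It differs from compound 2 as follows: hydrogen in place of 3-methylbut-2-en-1-yl on a saturated chain carbon bound to a double-bonded chain carbon. Among the compounds with values here, no measured step involves this chain or this place, so the only step available, the loss of formyl in compound 1 to compound 3, bears on it only loosely, showing that removing a group can cost a large share of inhibition. With the core of compound 2 kept intact, a moderate fall is expected for compound 4, giving an estimated 72% with a range from 40% to 95%, an expected step of a number 20.2 percentage points lower from compound 2 to compound 4 (beyond the scatter).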

Compound 4, a percentage reported as inhibition, at one concentration (the size of the read-out at that concentration, not a potency): 38.3%
Compound 4: middle estimate off by 33.7 percentage points, on the high side, outside the stated range (below it).
By their numbers in this assay, from the lowest: compound 3; then compounds 1 and 4 (each within the scatter of the next); then compound 2.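

In this assay, going by these compounds alone, replacing 3-methylbut-2-en-1-yl with hydrogen on a saturated chain carbon bound to a double-bonded chain carbon gives a number 53.9 percentage points lower from compound 2 to compound 4 (beyond the scatter), the first measured step at this place and one made with the core unchanged. The earlier step concerned only a formyl group on an aromatic carbon, whereas this one shows that the side chain itself matters on this core and that much of the high number of compound 2 depends on the 3-methylbut-2-en-1-yl. Nothing measured here speaks to the cause of this step.

On these data alone, whether a still longer chain, or a chain ending in an amine or a carboxylic acid, would hold or change the number at this place remains open. Also open, as far as these compounds go, is whether adding the same 3-methylbut-2-en-1-yl to the core of compound 1 would give a step of similar size.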